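Adding a Methyl Group to the Core of Compound 1

The source may report more compounds than this note shows. Statements on the series, on what has been measured and on what is new or still open speak of the compounds shown alone.

Of the compounds shown here, three built around a shared biaryl core have been tested in a functional assay on CHO cells for agonist activity at Free fatty acid receptor 1 (Rattus norvegicus), read by calcium flux; on this read-out higher numbers stand for an effect only at larger amounts of compound and lower numbers for an effect already at smaller amounts. Compound 1, with the structure `Cc1cccc(C)c1-c1cccc(COc2ccc(CCC(=O)O)cn2)c1`, gives 38 nM in this assay, the lowest of the three numbers. Compound 2, `Cc1cccc(C)c1-c1cccc(COc2ccc(CCC(=O)O)nc2)c1`, gives 210 nM, and compound 3, `Cc1cccc(C)c1-c1cccc(COc2ccc(CCC(=O)O)s2)c1`, gives 840 nM; both gaps to compound 1 are wider than the usual scatter, so compound 1 is the most potent of the three measured.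

Compound 4, with the structure `Cc1cc(OCc2cccc(-c3c(C)cccc3C)c2)ncc1CCC(=O)O`, has not yet been measured. It differs from compound 1 in a single place: methyl in place of hydrogen on an aromatic carbon. No comparable change between two measured compounds is available, so the effect of this methyl group cannot be read from the data gathered so far.

Given the size of the change, the step of a 1.3-fold higher number from compound 1 to compound 4 (0.12 log units; within the scatter) is expected to be small, in either direction or none beyond the scatter. Compound 4 is therefore estimated to give about 50 nM in this assay, with a plausible range from 15 nM to 170 nM.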

Compound 4, half-maximal effective concentration: 130 nM
For compound 4 the middle estimate is 2.6-fold (0.41 log units) below the measured one; measured number inside the range.
By their numbers in this assay, from the lowest: compound 1; then compounds 4 and 2 (each within the scatter of the next); then compound 3.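

In this assay, a methyl group in place of hydrogen on the aromatic carbon ortho to the 2-carboxyethyl group and opposite the ring nitrogen brings a 3.4-fold higher number from compound 1 to compound 4 (0.53 log units; beyond the scatter), a modest step but one that lies beyond the scatter. This position is therefore not indifferent to substitution: a methyl group alone is enough to shift the number towards needing more compound for the same effect. The data shown offer no measurement that would explain this shift.

On these data alone, whether a fluorine atom, a methoxy group or an ethyl group on this same carbon would move the number as far, less far or not at all remains open. Also open, as far as these compounds go, is whether a methyl group on another carbon of this ring would bring a similar step.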